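The compounds below may be only part of what the source reports. "The series", "measured", "known", "first", "only" and "open" are said of these compounds alone.

Compound 3 `CC(C)OC(=O)C1=CN(C(=O)c2ccc(F)cc2)CC(C)(C)c2cc(C#N)[nH]c21` gives 5 nM in an assay on HEK293 cells for agonist activity at Bile acid receptor (Homo sapiens), read by a luciferase reporter (on this read-out higher numbers stand for an effect only at larger amounts of compound and lower numbers for an effect already at smaller amounts), the lowest of the three numbers measured. Compound 1 `CC(C)OC(=O)C1CN(C(=O)C2CCCCC2)CC(C)(C)c2cc(C#N)[nH]c21` gives 1900 nM in this assay, and compound 2 `CC(C)OC(=O)C1CN(C(=O)c2ccc(C#N)cc2)CC(C)(C)c2cc(C#N)[nH]c21` gives 5700 nM; both stand far above compound 3, with compound 1 the nearer of the two. Compound 4 `CC(C)OC(=O)C1=CN(C(=O)c2cccc(C(F)(F)F)c2)CC(C)(C)c2cc(C#N)[nH]c21` has not yet been measured. It differs from compound 3 in one place: 3-(trifluoromethyl)phenyl in place of 4-fluorophenyl on a carbonyl carbon. For the measured compounds named here, the only measured step that bears on such an exchange is a 3.0-fold higher number from compound 1 to compound 2 (0.48 log units; beyond the scatter), where swapping the group on the same carbonyl carbon moved the number only modestly. Compound 3 and compound 4 share a core that differs from that of compound 1 and compound 2, so the comparison is indirect, and the direction for a ring-substituent swap cannot be read from one step alone. A change of similar modest size is therefore expected, a 3.0-fold higher number from compound 3 to compound 4 (0.48 log units; beyond the scatter), somewhat toward a higher number. Compound 4 is estimated at 15 nM, within a range from 4 nM to 60 nM.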

Compound 4, half-maximal effective concentration: 8.5 nM
The estimate for compound 4 lay 1.8-fold (0.25 log units) above the measured number, and the stated range covers the measured number.
By their numbers in this assay, from the lowest: compounds 3 and 4 (each within the scatter of the next); then compound 1; then compound 2.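

In this assay, exchanging 4-fluorophenyl for 3-(trifluoromethyl)phenyl on the carbonyl carbon gives a 1.7-fold higher number from compound 3 to compound 4 (0.23 log units; within the scatter), so this exchange leaves the number without a change that can be told from assay scatter. The earlier step, a 3.0-fold higher number from compound 1 to compound 2 (0.48 log units; beyond the scatter), replaced cyclohexyl with a phenyl ring on a different core; this step instead compares two substituted phenyl rings on the core of compound 3, and shows that the group with more heavy atoms is tolerated at this place. No available evidence accounts for this result.

From the compounds shown here alone, how an amine or a carboxylic acid on this phenyl ring, or a longer alkyl chain in place of the ring, would read on this core stays open. Also open, going by these compounds, is how cyclohexyl or 4-cyanophenyl would read on the core of compound 3.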